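Nitro to methyl on the fused benzene ring of the sulfonamide series

The source may report more compounds than this note shows. Statements on the series, on what has been measured and on what is new or still open speak of the compounds shown alone.

Measured so far in a functional assay on SK-OV-3 cells (Homo sapiens) for antiproliferative activity, read by MTT assay, with a stated time of 72 h; a lower number here means a stronger inhibitor, a higher number a weaker inhibitor:
compound 1 `O=[N+]([O-])c1ccc2c(c1)N(S(=O)(=O)c1ccc(-c3cnc(C4CC4)o3)cc1)CCCO2` gives 53 nM
compound 2 `O=[N+]([O-])c1ccc2c(c1)OCCCN2S(=O)(=O)c1ccc(-c2cnc(C3CC3)o2)cc1` gives 120 nM
compound 3 `O=S(=O)(c1ccc(-c2cnc(C3CC3)o2)cc1)N1CCCc2ccccc21` gives 47 nM

Compound 1 stands second highest of the three numbers. Its nearest neighbour is compound 3, whose value lies within the scatter of that of compound 1, so no order can be read between these two. Compound 2 stands furthest from compound 1, with a higher number beyond the scatter; the two share every group and differ only in how the nitro and the ring oxygen are arranged on the shared core. Compound 3 carries no nitro at all and no oxygen in its saturated ring, and still its value sits with that of compound 1, so the series gives no sign that the nitro is needed for the activity seen.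

The next compound, compound 4 `Cc1ccc2c(c1)N(S(=O)(=O)c1ccc(-c3cnc(C4CC4)o3)cc1)CCCO2`, is not yet measured. Its change from compound 1 is methyl in place of nitro on an aromatic carbon.

Among the compounds with values here, no measured pair makes exactly this change. Given that compound 3, lacking the nitro, gives 47 nM beside compound 1 at 53 nM, the step of a 1.1-fold higher number from compound 1 to compound 4 (0.05 log units; within the scatter) is expected to be small, in no clear direction, and within the scatter. On that basis compound 4 is estimated at 60 nM, with a range from 25 nM to 150 nM.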

Compound 4, half-maximal inhibitory concentration: 34 nM
Estimate against measurement, compound 4: 1.8-fold (0.25 log units) above; low and high end bracket the measured number.
By their numbers in this assay, from the lowest: compounds 4, 3 and 1 (each within the scatter of the next); then compound 2.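

In this assay, within the data shown here, methyl in place of nitro on this aromatic carbon gives a 1.6-fold lower number from compound 1 to compound 4 (0.19 log units; within the scatter) and is the first reading of this position from a pair that differs in one place only. No order can be read between compound 1 and compound 4, even though the change removes 3 heavy atoms and 2 hydrogen-bond acceptors and puts back 1 heavy atom with no hydrogen-bond acceptors. In this pair, then, the nitro is not required for activity at this level, which the earlier compounds could only hint at since none of them differed from compound 1 at this position alone, and nothing measured on either group accounts for the result.

Still open is whether an amine, a carboxylic acid or a longer chain on this same aromatic carbon would keep the value in this range, since nitro and methyl are the only groups shown there on this core. Also open is whether methyl in place of nitro would give a similar step on the arrangement of compound 2 at 120 nM in this assay, which has no methyl counterpart among the compounds shown.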